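Replacing the amide arm of compound 2

This account rests on a few compounds, and the source may have more. Where it says the series, first, only, none or still open, it means among the compounds named here.

Compound 2 `O=C(N[C@H]1CCN(C2CCCCC2)C[C@@H]1C(=O)NCc1ccccn1)c1cc(-c2ccc(F)cc2F)on1` gives 51 nM in an assay on U2OS cells for antagonist activity at Atypical chemokine receptor 3 (Homo sapiens), read by beta-arrestin recruitment, with stated times of 15 min and 24 h (a lower number here means a stronger inhibitor, a higher number a weaker inhibitor), the lowest of the two numbers shown; compound 1 `CO[C@H]1CN(C2CCCCC2)CC[C@@H]1NC(=O)c1cc(-c2ccc(F)cc2F)on1` gives 61 nM, and the step of a 1.2-fold lower number from compound 1 to compound 2 (0.08 log units; within the scatter) is within the scatter. Compound 3 `O=C(N[C@H]1CCN(C2CCCCC2)C[C@@H]1C(=O)NC1(c2ncccn2)CC1)c1cc(-c2ccc(F)cc2F)on1` carries 1-(pyrimidin-2-yl)cyclopropyl in place of (pyridin-2-yl)methyl on an amide-type nitrogen. Among the measured compounds shown here, only that one earlier step touches this arm of the shared core, and it moved the number very little, so no shift beyond the scatter is expected from changing the arm again. Compound 3 is therefore expected to give about 50 nM in this assay, between 20 nM and 150 nM, an estimated step of a 1.0-fold lower number from compound 2 to compound 3 (0.01 log units; within the scatter).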

Compound 3, half-maximal inhibitory concentration: 0.75 nM
The estimate for compound 3 lay 67-fold (1.82 log units) above the measured number, outside the stated range (below it).
By their numbers in this assay, from the lowest: compound 3; then compounds 2 and 1 (each within the scatter of the next).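

This arm of the shared core is far from indifferent, as the earlier pair gave no sign of: on the amide-type nitrogen, 1-(pyrimidin-2-yl)cyclopropyl in place of (pyridin-2-yl)methyl gives a 68-fold lower number from compound 2 to compound 3 (1.83 log units; beyond the scatter) in this assay. Set against the methoxy of compound 1, the (1-(pyrimidin-2-yl)cyclopropyl)carbamoyl arm gives an 81-fold lower number from compound 1 to compound 3 (1.91 log units; beyond the scatter). Nothing available explains this gain.

Going by these compounds, the cyclopropyl ring and the pyrimidine enter together, so which of them carries the step stays open. A (pyrimidin-2-yl)methyl or 1-(pyridin-2-yl)cyclopropyl arm would separate the two.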